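The source may report more compounds than this note shows. Statements on the series, on what has been measured and on what is new or still open speak of the compounds shown alone.

Compound 1, with the structure `COc1ccc(Nc2nnnn2-c2ccc(Br)cc2)cc1`, was tested in an ADME assay on V79 cells (Cricetulus griseus) for cytotoxicity, read by MTT assay, with a stated time of 72 h (on this read-out lower numbers stand for stronger inhibition and higher numbers for weaker inhibition), and compound 1 gave 125000 nM. Its one companion in this set is compound 2, `COc1ccc(-n2nnnc2Nc2ccccc2Cl)cc1`, and in this assay compound 2 gave 246000 nM. Compound 1 holds the lower of the two numbers, yet the gap to compound 2 lies within the usual scatter of repeated runs, so the two compounds cannot be told apart on this read-out. Among the measured compounds shown here, compound 2 also differs from compound 1 in more than one respect, so no single-point step can be drawn between them.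

The next compound, compound 3, has the structure `COc1ccc(Nc2nnnn2-c2cccc(Br)c2)cc1`. Its relation to compound 1 is a single rearrangement: 3-bromophenyl in place of 4-bromophenyl on an aromatic nitrogen. For the measured compounds named here, with no step between measured compounds to lean on, the account rests on the bare fact that the same atoms are present, joined differently, and the expectation is that the step from compound 1 to compound 3 stays within the scatter, expected at no change at the digits printed from compound 1 to compound 3 (within the scatter). Compound 3 is therefore estimated at 125000 nM, with a range from 50000 nM to 300000 nM.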

Compound 3, half-maximal inhibitory concentration: 124000 nM
Compound 3: the middle estimate sits 1.0-fold (0.00 log units) above what was measured, and the stated range covers the measured number.
By their numbers in this assay, from the lowest: compounds 3, 1 and 2 (each within the scatter of the next).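

In this assay, among the compounds shown here, the exchange of 4-bromophenyl for 3-bromophenyl on the aromatic nitrogen gives a 1.0-fold lower number from compound 1 to compound 3 (0.00 log units; within the scatter), and this is the first single-place step in the set. It shows that, for this pair, where the bromine sits on that phenyl ring does not separate the two compounds on this read-out, something the earlier pair could not show since those compounds differ in more than one respect. Nothing in the available data speaks to why the two numbers sit so close together.

What the compounds shown leave open is whether this tolerance belongs to the position or only to bromine, since one pair cannot say how a carboxylic acid, an amine or a longer alkyl chain on that phenyl ring would read in this cytotoxicity test. Also open, going by these compounds, is whether the same exchange would stay within the scatter on a different core, and whether any group at this place can move the number beyond the scatter at all.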